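Swapping the ring on sulfur in a nitroanilide series

A few compounds are considered here, and "the series" means these few. Any claim that something is new, unique, unknown or untested is made for them only; others in the source may bear on it.

Compound 1 `CC(O)(C[S+]([O-])c1ccc(C(F)(F)F)cn1)C(=O)Nc1ccc([N+](=O)[O-])cc1C(F)(F)F` gives > 100000 nM; > 100000 nM (2 entries) in a functional assay on VCaP cells (Homo sapiens) for antiproliferative activity; a higher number here means a weaker inhibitor, a lower number a stronger inhibitor; this is a limit of the assay, not a number.
Compound 2 `CC(O)(C[S+]([O-])c1ccc(C(F)(F)F)cc1)C(=O)Nc1ccc([N+](=O)[O-])cc1C(F)(F)F` gives 24200 nM in this assay.
Compound 3 `CC(O)(C[S+]([O-])c1ccccn1)C(=O)Nc1ccc([N+](=O)[O-])cc1C(F)(F)F` gives 100000 nM in this assay.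

Three compounds share one core and differ only in the aromatic ring attached to the sulfur. Compound 3 stands at the highest of the two numbers that were obtained; compound 1 gave only a limit. Within the data shown here, the one measured step, a 4.1-fold higher number from compound 2 to compound 3 (0.62 log units; beyond the scatter), shows that replacing 4-(trifluoromethyl)phenyl with pyridin-2-yl weakened the inhibitor by a modest amount that is nevertheless beyond the scatter.

Compound 4 `CC(O)(C[S+]([O-])c1ccccc1OC(F)(F)F)C(=O)Nc1ccc([N+](=O)[O-])cc1C(F)(F)F` has not been measured. Its structure differs from compound 3 as follows: 2-(trifluoromethoxy)phenyl in place of pyridin-2-yl on a sulfur. This change runs in the opposite sense to the measured step: a nitrogen-containing ring leaves and a carbon-only ring carrying a trifluoromethoxy group enters. Because a 4.1-fold higher number from compound 2 to compound 3 (0.62 log units; beyond the scatter) went upward when a fluorinated carbon ring was exchanged for the pyridine, the reverse exchange is expected to move the number downward by a comparable, modest amount, roughly a 3.3-fold lower number from compound 3 to compound 4 (0.52 log units; beyond the scatter). For compound 4 the estimate in this assay is therefore 30000 nM, with a range from 8000 nM to 100000 nM.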

Compound 4, half-maximal inhibitory concentration: 20700 nM
Compound 4: middle estimate off by 1.4-fold (0.16 log units), on the high side; the measured number falls inside the stated range.
By their numbers in this assay, from the lowest: compounds 4 and 2 (each within the scatter of the next); then compound 3.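

In this assay, 2-(trifluoromethoxy)phenyl in place of pyridin-2-yl on the sulfur gives a 4.8-fold lower number from compound 3 to compound 4 (0.68 log units; beyond the scatter) and so lowers the number by a modest amount beyond the scatter. Among these compounds, this shows that the number at this position can be brought down with a ring of carbon only that carries a group other than the 4-(trifluoromethyl) of the earlier compounds. The comparison of the two fluorinated rings gives a 1.2-fold lower number from compound 2 to compound 4 (0.07 log units; within the scatter) and so does not separate them in this assay, although the fluorinated groups differ in both name and place on the ring; no supporting measurement explains the behaviour of any of these rings.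

Going by these compounds, what remains open is whether a carbon-only ring is enough by itself, and a plain phenyl ring on the sulfur would test that directly against both fluorinated rings. It is also open how this position would respond to a ring bearing an amine or a carboxylic acid, groups unlike anything in the compounds shown.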